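This account rests on a few compounds, and the source may have more. Where it says the series, first, only, none or still open, it means among the compounds named here.

Three compounds share one core: compound 1 (`CCOc1ncc(-c2nc(C(F)(F)F)sc2N2CCN(C(=O)Cn3nc(C)nc3C)[C@H](C)C2)cn1`), compound 2 (`COc1ncc(-c2nc(C(F)(F)F)sc2N2CCN(C(=O)Cn3nc(C)nc3C)[C@H](C)C2)cn1`) and compound 3 (`Cc1nc(C)n(CC(=O)N2CCN(c3sc(C(F)(F)F)nc3-c3cnc(C4CC4)nc3)C[C@H]2C)n1`). In a toxicity assay on microsomes from liver (Homo sapiens) for metabolic stability, read by LC-MS, using NADPH, tested at 1 uM (a higher number here means faster removal of the compound, a lower number slower removal), compound 1 gives < 10 mL.min-1.g-1 as a limit of the assay, not a number. Compound 2 gives < 10 mL.min-1.g-1 in the same test, also a limit. Compound 3 gives < 10 mL.min-1.g-1 there, so it too stands only at a limit. The whole series can be summed up in one line (the limit of < 10 mL.min-1.g-1 in this assay, at which 3 of the 3 values shown sit).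

Compound 4 (`COc1ccc(-c2nc(C(F)(F)F)sc2N2CCN(C(=O)Cn3nc(C)nc3C)[C@H](C)C2)cn1`) carries 6-methoxypyridin-3-yl in place of 2-cyclopropylpyrimidin-5-yl on an aromatic carbon of the core (6-methoxypyridin-3-yl in place of 2-cyclopropylpyrimidin-5-yl on an aromatic carbon). For the measured compounds named here, three measured steps bear on this change (a step that the two limits leave unreadable from compound 1 to compound 2; a step that the two limits leave unreadable from compound 1 to compound 3; a step that the two limits leave unreadable from compound 2 to compound 3). None has a readable size, and none gives a direction. The last of them is the closest guide, since it connects a methoxy group with a cyclopropyl group while the read-out stays at the limit. Going by the values given here, no measured compound carries 6-methoxypyridin-3-yl, so the expectation is uncertain. The estimated change is small, with only a slight lean towards faster removal (a step that the limit leaves unreadable from compound 3 to compound 4). Compound 4 is expected to give about 9 mL.min-1.g-1 in this assay, with an estimated range from 4 mL.min-1.g-1 to 25 mL.min-1.g-1 (and quite possibly only a limit again).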

Compound 4, intrinsic clearance in microsomes: < 10 mL.min-1.g-1
Compound 4: no number, only a limit; the forecaster's own chance of this, stated with the estimate: 60%; the middle value is on the limit's open side.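

In this assay compound 4 gives < 10 mL.min-1.g-1, which is a limit and not a number. No step from compound 1, compound 2 or compound 3 to compound 4 can be read, and the series stays where it was: the limit of < 10 mL.min-1.g-1 in this assay, at which 4 of the 4 values shown sit.

Still open, on these data alone, is how fast each of these four compounds is actually removed, and so whether 6-methoxypyridin-3-yl changes removal at all compared with the groups it replaces.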